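Swapping tert-butyl for 2-fluorophenyl on the amide carbonyl

This account rests on a few compounds, and the source may have more. Where it says the series, first, only, none or still open, it means among the compounds named here.

Of the compounds shown here, three sharing one core have been measured in an assay on membranes from striatum (strain Sprague-Dawley) for displacement of a labelled ligand from sodium-dependent dopamine transporter (Rattus norvegicus), read by scintillation counting, with a stated time of 120 min; on this read-out lower numbers stand for stronger inhibition and higher numbers for weaker inhibition. Compound 1 `O=C(c1ccccc1)N1CCC(NCC[S+]([O-])C(c2ccc(F)cc2)c2ccc(F)cc2)CC1` gives 79.1 nM, compound 2 `O=C(c1ccc(F)cc1)N1CCC(NCC[S+]([O-])C(c2ccc(F)cc2)c2ccc(F)cc2)CC1` gives 77.2 nM, and compound 3 `CC(C)(C)C(=O)N1CCC(NCC[S+]([O-])C(c2ccc(F)cc2)c2ccc(F)cc2)CC1` gives 10200 nM, the highest number of the three. Compound 4 `O=C(c1ccccc1F)N1CCC(NCC[S+]([O-])C(c2ccc(F)cc2)c2ccc(F)cc2)CC1` differs from compound 3 by 2-fluorophenyl in place of tert-butyl on a carbonyl carbon. For the measured compounds named here, the steps that bear on this are a 130-fold higher number from compound 1 to compound 3 (2.11 log units; beyond the scatter) and a 130-fold higher number from compound 2 to compound 3 (2.12 log units; beyond the scatter), both large; the present change runs the opposite way, returning an aromatic ring to the carbonyl carbon. The step of a 1.0-fold lower number from compound 1 to compound 2 (0.01 log units; within the scatter) shows that a fluorine on an aromatic carbon stayed within the scatter, though that was a 4-fluorophenyl and compound 4 carries a 2-fluorophenyl. A large downward step is therefore expected, a 110-fold lower number from compound 3 to compound 4 (2.05 log units; beyond the scatter). Compound 4 is estimated at 90 nM, between 35 nM and 300 nM.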

Compound 4, inhibition constant: 604 nM
Beside the measured number, compound 4's estimate is 6.7-fold (0.83 log units) below it, and the stated range ends below it.
By their numbers in this assay, from the lowest: compounds 2 and 1 (each within the scatter of the next); then compound 4; then compound 3.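

An aromatic ring on the carbonyl carbon again gives a far lower number than tert-butyl, with a 17-fold lower number from compound 3 to compound 4 (1.23 log units; beyond the scatter) on this change, yet 2-fluorophenyl does not match the other two aromatic groups. Fluoro on the ring now matters, with a 7.6-fold higher number from compound 1 to compound 4 (0.88 log units; beyond the scatter) and a 7.8-fold higher number from compound 2 to compound 4 (0.89 log units; beyond the scatter) as the two steps, whereas the 4-fluorophenyl of compound 2 stayed within the scatter of compound 1, so where the fluorine sits changes the result. Nothing available explains this difference.

Going by these compounds, whether methyl or chlorine in place of that fluorine would cost as much remains open.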